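The source may hold more compounds than are shown below. What is called first, only, known or untested is meant among the compounds shown, and "the series" means these compounds.

Compound 1, `COc1cc2c(/C=C3/C(=O)Nc4ccc(O)cc43)c(Cl)n(Cc3cc(OC)c(OC)c(OC)c3)c2cc1C`: in a functional assay on cells (Cancer cell lines, Homo sapiens) for cytotoxicity, with a stated time of 48 h (on this read-out lower numbers stand for stronger inhibition of growth and higher numbers for weaker inhibition of growth), compound 1 gives 43700 nM.
Compound 2, `O=C1/C(=C/c2c(Cl)[nH]c3ccccc23)c2ccccc2N1Cc1ccccc1`: in this assay compound 2 gives 79400 nM.
Compound 3, `COc1c(/C=C2/C(=O)Nc3ccccc32)c2ccccc2n1-c1ccccc1`: in this assay compound 3 gives 4070 nM.

Among these three, compound 3 has the lowest number, and its gaps to compound 1 and to compound 2 both lie beyond the scatter of repeated measurements, so compound 3 is the strongest growth inhibitor of the group. Compound 4, `COc1c(/C=C2/C(=O)Nc3ccc(Cl)cc32)c2ccccc2n1-c1ccccc1`, has not yet been measured. It differs from compound 3 in one place: chloro in place of hydrogen on an aromatic carbon. Within the data shown here, no pair of measured compounds shows what such a single swap does here, so there is no directly comparable step to lean on. A single chlorine added to a ring of the shared core is a small change, and in this assay the step from compound 3 to compound 4 is expected to be a 1.4-fold lower number from compound 3 to compound 4 (0.13 log units; within the scatter), within or close to the usual scatter, leaning very slightly toward a lower number. Compound 4 is therefore estimated at 3000 nM, in a range from 900 nM to 10000 nM.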

Compound 4, concentration for total growth inhibition: 24000 nM
Estimate against measurement, compound 4: 8.0-fold (0.90 log units) below; measured number above the stated range.
By their numbers in this assay, from the lowest: compound 3; then compounds 4, 1 and 2 (each within the scatter of the next, the first and the last beyond it).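

Adding a single chlorine atom is a small change, yet this position on the shared core is not indifferent to it. In this assay, chloro in place of hydrogen on an aromatic carbon of the six-membered carbon ring gives a 5.9-fold higher number from compound 3 to compound 4 (0.77 log units; beyond the scatter) and so weaker inhibition of growth, a modest step but a real one. No supporting measurement is available that could explain this step.

A single swap at a single carbon cannot show whether the weakening belongs to chloro in particular or would follow from any group placed there, and a fluoro group or an amine on the same carbon would help separate those two readings. As far as these compounds go, it also remains open whether chloro would have the same effect on other carbons of this ring, or on a core carrying different groups elsewhere.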